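Second chloro on the shared core's aryl arm

This account rests on a few compounds, and the source may have more. Where it says the series, first, only, none or still open, it means among the compounds named here.

The shared core carries two aryl arms, each joined through a double-bonded chain carbon, and the compounds differ only in the arm that varies. Compound 1 `C=CCn1c(=O)/c(=C\c2ccccc2OC)[nH]c(=O)/c1=C\c1ccccc1OC` is the reference point; in a functional assay on A549 cells (Homo sapiens) for cytotoxicity, read by CCK-8 assay, with a stated time of 72 h (on this read-out lower numbers stand for stronger inhibition and higher numbers for weaker inhibition), compound 1 gives 22400 nM. Compound 2 `C=CCn1c(=O)/c(=C\c2ccccc2F)[nH]c(=O)/c1=C\c1ccccc1OC`, which carries a 2-fluorophenyl on that arm, is reported as "not active" (no number reported) in this assay, with no number given. Among the measured compounds shown here, compound 3 `C=CCn1c(=O)/c(=C\c2cccc(Cl)c2)[nH]c(=O)/c1=C\c1ccccc1OC` gives 5200 nM in this assay, the lowest of the two numbers recorded; the only measured step that touches it is a 4.3-fold lower number from compound 1 to compound 3 (0.63 log units; beyond the scatter).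

Compound 4 `C=CCn1c(=O)/c(=C\c2ccc(Cl)c(Cl)c2)[nH]c(=O)/c1=C\c1ccccc1OC` takes the next step: chloro in place of hydrogen on an aromatic carbon. For the measured compounds named here, no measured pair shows what a second chloro does once one is already in place, so the step from compound 1 to compound 3 is the only guide, and it concerns a different change. The expectation for compound 4 is therefore cautious: a step of a 1.5-fold lower number from compound 3 to compound 4 (0.17 log units; within the scatter) in this assay, small and possibly within the scatter. In this assay compound 4 is expected to give about 3500 nM, with a likely range from 1200 nM to 10000 nM.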

Compound 4, half-maximal inhibitory concentration: "not active" (no number reported)
The entry for compound 4 holds no number, and the estimate cannot be compared.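

Among the compounds shown here, compound 4 is reported as "not active" in this assay and carries no number, so no step between compound 3 and compound 4 can be read. No measurement shown accounts for this result. The compounds shown leave open how far the 3,4-dichlorophenyl arm of compound 4 stands from the 3-chlorophenyl arm of compound 3 in numbers.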